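The source may hold more compounds than are shown below. What is called first, only, known or untested is meant among the compounds shown, and "the series" means these compounds.

Working notes on the pyrazolyl chalcone series.

Compound 1 `COc1cc(-c2cc(/C=C/C(=O)c3ccc(Cl)c(Cl)c3)[nH]n2)cc(OC)c1OC` carries a 3,4-dichlorophenyl on the carbonyl carbon and a trimethoxyphenyl on the shared core. In a functional assay on OVCAR-5 cells (Homo sapiens) for inhibition, read by sulforhodamine B assay, with a stated time of 48 h (a lower number here means that less compound is tolerated, a higher number that more compound is tolerated), compound 1 gives only a limit, > 100000 nM, and no number. Among the measured compounds shown here, this is the line (the limit of > 100000 nM in this assay, at which 1 of the 3 values shown sits); compound 1 is the one member of the set that stands there, so it sits at the weak end of what has been measured. Compound 2 `COc1ccc(-c2cc(/C=C/C(=O)c3ccc(N)cc3)[nH]n2)cc1OC` gives 36300 nM in this assay, and compound 3 `COc1ccc(-c2cc(/C=C/C(=O)c3cc(OC)c(OC)c(OC)c3)[nH]n2)cc1OC` gives 13700 nM in this assay; both carry a dimethoxyphenyl on the shared core and an oxygen- or nitrogen-bearing aryl group on the carbonyl carbon, and both return measurable numbers where compound 1 does not. For the measured compounds named here, nothing in the set separates the effect of the carbonyl-side aryl group from that of the core-side aryl group, since no two measured compounds differ in one place only.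

Compound 4 `COc1ccc(C(=O)/C=C/c2cc(-c3cc(OC)c(OC)c(OC)c3)n[nH]2)cc1OC` differs from compound 1 in one place: 3,4-dimethoxyphenyl in place of 3,4-dichlorophenyl on a carbonyl carbon. Given that compounds 2 and 3 with oxygen- or nitrogen-bearing aryl ketones both fall inside the measurable range, the step is expected to move toward tolerance of less compound, beyond the usual scatter, though the size is uncertain with no matched step to lean on. For compound 4 the estimate is 30000 nM in this assay, within 8000 nM to 100000 nM, which corresponds to an expected step of an at least 3.3-fold lower number from compound 1 to compound 4 (0.52 log units; beyond the scatter). A limit-only result for compound 4 remains a real possibility.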

Compound 4, concentration lethal to 50% of the cells: 5750 nM
For compound 4 the middle estimate is 5.2-fold (0.72 log units) above the measured one; the measured number lies below the stated range.
By their numbers in this assay, from the lowest: compound 4; then compound 3; then compound 2. At a limit, above all of these: compound 1.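

In this assay, among the compounds shown here, this is the first step with only one place changed: 3,4-dimethoxyphenyl in place of 3,4-dichlorophenyl on a carbonyl carbon gives an at least 17-fold lower number from compound 1 to compound 4 (1.24 log units; beyond the scatter). The aryl group on the carbonyl carbon can therefore move the number beyond the scatter on its own, with the trimethoxyphenyl on the shared core held fixed, which compounds 2 and 3 could not show. Compound 1 gives only a limit, > 100000 nM, so the step sets a minimum size and not a measured one, and compound 1 remains alone at that limit: the limit of > 100000 nM in this assay, at which 1 of the 4 values shown sits.

The compounds shown leave open whether the same change gives a step of similar size when a dimethoxyphenyl, as in compounds 2 and 3, sits on the shared core, and whether the methoxy groups or the removal of the chlorines accounts for the step. Also open, going by these compounds, is how an unsubstituted phenyl, a phenyl with a single methoxy group or a phenyl bearing a carboxylic acid on the carbonyl carbon would read in this assay.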